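The source may report more compounds than this note shows. Statements on the series, on what has been measured and on what is new or still open speak of the compounds shown alone.

Measured compounds:
- compound 1, `O=c1cc(CNCc2ccccc2O)oc2ccc(O)c(O)c12`: in an ADME assay on Huh-7 cells (Homo sapiens) for cytotoxicity (a higher number here means that more compound is tolerated, a lower number that less compound is tolerated), compound 1 gives > 100000 nM, a limit of the assay.
- compound 2, `O=c1cc(CNCc2cccc(Br)c2)oc2ccc(O)c(O)c12`: in this assay compound 2 gives > 100000 nM, a limit of the assay.
- compound 3, `O=c1cc(CNCc2cccc(O)c2)oc2ccc(O)c(O)c12`: in this assay compound 3 gives > 100000 nM, a limit of the assay.

Compound 3 therefore stands only at a limit, not at a number, and the same holds for the two other compounds that share its core: the limit of > 100000 nM in this assay, at which 3 of the 3 values shown sit. Because of this, the three steps among the measured compounds cannot be read: a step that the two limits leave unreadable from compound 1 to compound 2, a step that the two limits leave unreadable from compound 1 to compound 3 and a step that the two limits leave unreadable from compound 2 to compound 3 all run between two limits, and their sizes stay hidden.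

Compound 4, `Cc1ccc(CNCc2cc(=O)c3c(O)c(O)ccc3o2)cc1`, has not yet been measured in this assay. It differs from compound 3 in one place: 4-methylphenyl in place of 3-hydroxyphenyl on a saturated chain carbon bound to an amine nitrogen. Within the data shown here, the steps that bear on it are those among compounds 1, 2 and 3, where a 2-hydroxyphenyl, a 3-bromophenyl and a 3-hydroxyphenyl on the same saturated chain carbon bound to an amine nitrogen all left the value at the limit. None of them gives a readable size, so no direction can be drawn from them.

Compound 4 is expected to sit at the limit as well, estimated at 100000 nM with a range from 50000 nM to 200000 nM. The step that this estimate means, a number no higher from compound 3 to compound 4 (the limit leaves the size open), is expected to be no step beyond the scatter.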

Compound 4, half-maximal cytotoxic concentration: > 100000 nM
Compound 4 was reported as a limit; the forecaster's own chance of this, stated with the estimate: 85%; the middle value lies on the limit itself.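

In this assay compound 4 gives > 100000 nM as a limit of the assay. Among these compounds, no step among compound 1, compound 2, compound 3 and compound 4 can be read, because all four rest at one limit: the limit of > 100000 nM in this assay, at which 4 of the 4 values shown sit. The compounds shown leave open where the half-maximal cytotoxic concentration of each lies, and whether the group on the saturated chain carbon bound to an amine nitrogen changes it.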